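A few compounds are considered here, and "the series" means these few. Any claim that something is new, unique, unknown or untested is made for them only; others in the source may bear on it.

Two measured compounds frame this account. Compound 1 `O=c1c(-c2ccc(O)cc2)coc2cc(OCCCCCCBr)ccc12` carries a bromo on the chain, and in a functional assay on mitochondria (Cricetulus griseus) for inhibition of Monoamine oxidase (Homo sapiens), tested at 3 uM (a higher number here means a stronger effect of the compound at the concentration tested, a lower number a weaker effect), compound 1 gives 88.5%. Compound 2 `O=C(O)CCCCCCCCCOc1ccc2c(=O)c(-c3ccc(O)cc3)coc2c1` carries the longer carboxylic chain, and in this assay compound 2 gives 89.6%. Compound 2 thus holds the higher of the two numbers, but the step of a number 1.1 percentage points higher from compound 1 to compound 2 (within the scatter) is within the scatter, so the two compounds cannot be ranked against each other in this assay.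

The unmeasured compound 3 `O=C(O)CCCCCCOc1ccc2c(=O)c(-c3ccc(O)cc3)coc2c1` differs from compound 2 in one place: carboxy in place of 3-carboxypropyl on a saturated chain carbon, six bonds along the chain from an oxygen on an aromatic ring. Going by the values given here, no measured step shortens the chain in this way; the only step in hand, a number 1.1 percentage points higher from compound 1 to compound 2 (within the scatter), swaps the end group of the chain while leaving its length untouched and shows no effect beyond the scatter. The shared core and the carboxylic acid at the chain end remain in compound 3, so a shift beyond the scatter in this assay is not expected, though the shortened chain leaves room for a modest drop. The estimated step is a number 7.6 percentage points lower from compound 2 to compound 3 (within the scatter). For compound 3 the expected inhibition in this assay is 82%, with a range from 62% to 95%.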

Compound 3, a percentage reported as inhibition, at one concentration (the size of the read-out at that concentration, not a potency): 87.4%
The estimate for compound 3 lay 5.4 percentage points below the measured number, and the stated range covers the measured number.
By their numbers in this assay, from the lowest: compounds 3, 1 and 2 (each within the scatter of the next).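

Within this assay the carboxylic acid chain tolerates shortening at this position: carboxy in place of 3-carboxypropyl gives a number 2.2 percentage points lower from compound 2 to compound 3 (within the scatter), so across this span of chain lengths the read-out does not respond to the length of the chain. Compound 3 also adds a cleaner comparison of the end group, as it carries its carboxy on the same saturated chain that carries the bromo in compound 1, and that swap gives a number 1.1 percentage points lower from compound 1 to compound 3 (within the scatter), so at this chain length neither the bromo nor the carboxy sets the two compounds apart. No information is at hand on why the read-out stays level across these changes.

The three compounds therefore cannot be ranked, and since each number is the size of an effect at one concentration, any differences in potency among them remain hidden. Still open, going by these compounds, is whether a much shorter carboxymethyl chain, or an amine or a hydroxyl at the chain end, would stay level with these compounds or finally move the read-out beyond the scatter.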